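Propargyl Ether Replaces Hydroxyethyl Ether on the Cyclic Sulfamide

This account rests on a few compounds, and the source may have more. Where it says the series, first, only, none or still open, it means among the compounds named here.

Compound 1 `O=C1c2ccccc2NS(=O)(=O)N1COCCO` is tested in a functional assay on HEL cells (Homo sapiens) for cytotoxicity (a lower number here means that less compound is tolerated, a higher number that more compound is tolerated), and gives only a limit of the assay, > 50 ug/mL. Compound 2 `O=C1NS(=O)(=O)N(COCc2ccccc2)c2ccccc21` likewise reaches only the limit > 50 ug/mL in this assay. Going by the values given here, compound 3 `C#CCOCN1c2ccccc2C(=O)N(Cc2ccccc2)S1(=O)=O` gives 50 ug/mL in this assay, the one plain number among the three. Compound 1 thus stands at the limit of > 50 ug/mL in this assay, at which 2 of the 3 values shown sit. Compound 4 `C#CCOCN1C(=O)c2ccccc2NS1(=O)=O` differs from compound 1 by ethynyl in place of hydroxymethyl on a saturated chain carbon bound to an oxygen on a saturated carbon. Among the compounds with values here, no two measured compounds differ in a single place, so no measured step is known. Compound 3, which carries the same propargyloxymethyl group, gives 50 ug/mL. On that basis the step of a number no higher from compound 1 to compound 4 (the limit leaves the size open) is expected to be none beyond the scatter. Compound 4 is estimated at 50 ug/mL, within 25 ug/mL to 100 ug/mL, with a limit again a likely outcome.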

Compound 4, minimum cytotoxic concentration: > 50 ug/mL
Compound 4 gave a limit, no number (the forecaster's own chance of this, stated with the estimate: 60%); the middle value lies on the limit itself.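

Going by these compounds alone, compound 1 and compound 4 both give only a limit in this assay, and no step between them can be read. The compounds shown leave open whether ethynyl in place of hydroxymethyl alters tolerance at all.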